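A few compounds are considered here, and "the series" means these few. Any claim that something is new, unique, unknown or untested is made for them only; others in the source may bear on it.

Compound 1, `CCCn1ccnc1-c1cc(OC)c(OC)c(OC)c1`, in a functional assay on MDA-MB-231 cells (Homo sapiens) for antiproliferative activity, read by MTT assay, with a stated time of 72 h (on this read-out lower numbers stand for stronger inhibition and higher numbers for weaker inhibition), gives > 100000 nM, a limit of the assay.
Compound 2, `COc1cc(-c2nccn2C(C)C)cc(OC)c1OC`, in this assay gives > 100000 nM, a limit of the assay.
Compound 3, `COc1cc(-c2nccn2CC(C)C)cc(OC)c1OC`, in this assay gives > 100000 nM, a limit of the assay.

All three measured compounds share one core and differ only in the group on the aromatic nitrogen of the five-membered ring. None of them yields a number: each sits at the limit of > 100000 nM in this assay, at which 3 of the 3 values shown sit. Compound 3 therefore stands nowhere on a scale; its value is only a limit, and the two other values are limits as well. The three measured steps are a step that the two limits leave unreadable from compound 1 to compound 2, a step that the two limits leave unreadable from compound 1 to compound 3 and a step that the two limits leave unreadable from compound 2 to compound 3; none of them can be read for size or direction, so none tells how the next change will act.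

The step to compound 4, `COc1cc(-c2nccn2-c2ccc(C)cc2)cc(OC)c1OC`, is 4-methylphenyl in place of isobutyl on an aromatic nitrogen. This is a larger change than any of the measured steps, which moved only between small saturated chains. The measured data give no footing for it; the expectation below rests only on the fact that every chain so far left the compound at the limit.

In this assay compound 4 is expected to give 60000 nM, within 3000 nM to 300000 nM, which would be an estimated step of an at least 1.6-fold lower number from compound 3 to compound 4 (0.22 log units; that floor lies within the scatter).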

Compound 4, half-maximal inhibitory concentration: 4100 nM
For compound 4 the middle estimate is 15-fold (1.17 log units) above the measured one; low and high end bracket the measured number.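

On an aromatic nitrogen of the five-membered ring, the group turns out to matter in this assay: 4-methylphenyl in place of isobutyl gives an at least 24-fold lower number from compound 3 to compound 4 (1.38 log units; beyond the scatter). The comparison with the two other chains reads the same way, with 4-methylphenyl in place of isopropyl giving an at least 24-fold lower number from compound 2 to compound 4 (1.38 log units; beyond the scatter) and in place of propyl giving an at least 24-fold lower number from compound 1 to compound 4 (1.38 log units; beyond the scatter). The earlier compounds could show only that three small saturated chains left the value unreadable, and the steps among them still cannot be read; compound 4 now shows that a six-membered aromatic ring of carbon only on this nitrogen goes with a real number, while the other compounds remain at a limit: the limit of > 100000 nM in this assay, at which 3 of the 4 values shown sit.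

With a single ring-bearing group shown, the compounds leave open whether the ring alone goes with this change or whether its methyl takes part, a question that plain phenyl, 4-methoxyphenyl or 4-chlorophenyl on the same nitrogen would address. They also leave open whether the ring must sit directly on the nitrogen, as it does in compound 4, or could stand one carbon away, as in a benzyl group.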